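A Halogen Swap on the Arylidene Arm

The source may report more compounds than this note shows. Statements on the series, on what has been measured and on what is new or still open speak of the compounds shown alone.

Within the data shown here, compound 1 `Cc1ccc2c(c1)/C(=N/NC(=S)N/N=C/c1c(Cl)cccc1Cl)C(=O)N2` is the only compound with a numerical result in a functional assay on COS-7 cells (Chlorocebus aethiops) for inhibition, read by MTT assay (on this read-out higher numbers stand for weaker inhibition and lower numbers for stronger inhibition), where compound 1 gives 3870 nM. Compound 2 `COc1ccc(/C=N/NC(=S)N/N=C2\C(=O)Nc3ccc(C)cc32)c(OC)c1` reaches in this assay only a limit, > 50000 nM, and not a number. Compound 3 `Cc1ccc2c(c1)/C(=N/NC(=S)N/N=C/c1ccc(Br)cc1)C(=O)N2` carries 4-bromophenyl in place of 2,6-dichlorophenyl on a carbon with a double bond to nitrogen. Among the measured compounds shown here, no measured pair shows a change of this kind, so the expected step is a 2.1-fold higher number from compound 1 to compound 3 (0.32 log units; beyond the scatter), leaning toward weaker inhibition but with wide uncertainty. Compound 3 is therefore estimated at 8000 nM in this assay, with a range from 2000 nM to 40000 nM.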

Compound 3, half-maximal inhibitory concentration: > 50000 nM
Compound 3: a limit, no number (the forecaster's own chance of this, stated with the estimate: 25%); middle value at least 6.2-fold (0.79 log units) from the limit.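

The place on the carbon with a double bond to nitrogen proves sensitive in this assay: 4-bromophenyl in place of 2,6-dichlorophenyl gives an at least 12-fold higher number from compound 1 to compound 3 (1.11 log units; beyond the scatter), the first step measured here. Compound 3 gives only a limit, > 50000 nM, so the step has a floor but no upper end. The true size of the step stays unknown: the limit of > 50000 nM in this assay, at which 2 of the 3 values shown sit.

As far as these compounds go, whether the loss follows from the chlorine atoms leaving or the bromine entering stays open, since both change at once. From the compounds shown here alone, how an amine or a carboxylic acid on this phenyl ring would read also stays open.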